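The source may hold more compounds than are shown below. What is called first, only, known or untested is meant among the compounds shown, and "the series" means these compounds.

Measured compounds:
Compound 1, `O=CN1CCC[C@H]1COCCCCCC/C=C/c1ccc(-c2ccccc2)cc1`, gives 53300 nM in a functional assay on BXPC-3 cells (Homo sapiens) for inhibition, read by XTT assay, with a stated time of 72 h; on this read-out higher numbers stand for weaker inhibition and lower numbers for stronger inhibition.
Compound 2, `O=CN1CCC[C@H]1COCCCCCCCCC/C=C/c1ccc(-c2ccccc2)cc1`, gives 66700 nM in this assay.
Compound 3, `CC(=O)N1CCC[C@H]1COCCCCCC/C=C/c1ccc(-c2ccccc2)cc1`, gives 50000 nM in this assay.

Compound 3 arises from compound 1 by one change, (methyl in place of hydrogen on a carbonyl carbon). The step it made, a 1.1-fold lower number from compound 1 to compound 3 (0.03 log units; within the scatter), is within the scatter, so the two values cannot be told apart. Compound 2 carries the same formyl group as compound 1, but the difference between the two cores is not broken down here. Compound 4, `CC(=O)N1CCC[C@H]1COCCCCCCCCC/C=C/c1ccc(-c2ccccc2)cc1`, arises from compound 2 by methyl in place of hydrogen on a carbonyl carbon, the same change at the same place. For compound 4 the expected step is a 1.1-fold lower number from compound 2 to compound 4 (0.05 log units; within the scatter), and this rests on the measured step of a 1.1-fold lower number from compound 1 to compound 3 (0.03 log units; within the scatter), which stayed within the scatter. Compound 4 is therefore estimated to give 60000 nM in this assay, with a range from 30000 nM to 120000 nM.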

Compound 4, half-maximal inhibitory concentration: 56700 nM
Compound 4: the middle estimate sits 1.1-fold (0.02 log units) above what was measured; the range from low to high includes it.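

In this assay, methyl in place of hydrogen on the carbonyl carbon gives a 1.2-fold lower number from compound 2 to compound 4 (0.07 log units; within the scatter), so the two values cannot be told apart. Set beside the earlier step, the change looks the same on both cores: the same change on two cores in this assay, a 1.1-fold lower number (0.03 log units; within the scatter) from compound 1 to compound 3 and a 1.2-fold lower number (0.07 log units; within the scatter) from compound 2 to compound 4, 1.1-fold (0.04 log units) apart, within the scatter of two such steps. This shows that the swap from formyl to acetyl carried over on these two cores, but only as a step too small to read, so it does not show that a real change in activity would carry over, or that other cores would behave alike.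

The compounds shown leave open whether another group on this carbonyl carbon, such as a longer chain or an amine, would move the number beyond the scatter.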